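The source may hold more compounds than are shown below. What is called first, only, known or untested is meant among the compounds shown, and "the series" means these compounds.

In a functional assay on A2780 cells (Homo sapiens) for antiproliferative activity, read by MTT assay, with a stated time of 72 h (on this read-out higher numbers stand for weaker inhibition and lower numbers for stronger inhibition), compound 3 `O=C(c1cc2ccccc2o1)N1N=C(c2ccc(F)cc2)CC1c1ccc([N+](=O)[O-])cc1` reads > 50 ug/mL, which is a limit of the assay and not a number. Compound 2 `O=C(c1cc2ccccc2o1)N1N=C(c2ccc(F)cc2)CC1c1ccc(Cl)cc1` reads > 50 ug/mL, also a limit. Within the data shown here, the one measured step, a step that the two limits leave unreadable from compound 2 to compound 3, therefore gives no size to carry forward. Compound 4 `O=C(c1cc2ccccc2o1)N1N=C(c2ccc(F)cc2)CC1c1ccccc1Cl` differs from compound 3 by 2-chlorophenyl in place of 4-nitrophenyl on a saturated ring carbon. Compound 1 `O=C(c1cc2ccccc2o1)N1N=C(c2ccc(Cl)cc2)CC1c1ccccc1Cl` carries the same 2-chlorophenyl and gives 44.8 ug/mL, so compound 4 is expected to land near that value. The expected move in this assay is an at least 1.1-fold lower number from compound 3 to compound 4 (0.04 log units; that floor lies within the scatter), towards slightly stronger inhibition, though it may stay within the scatter. For compound 4 the estimated value is 45 ug/mL, with an expected range of 25 ug/mL to 75 ug/mL.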

Compound 4, half-maximal inhibitory concentration: 45.2 ug/mL
For compound 4 the middle estimate is 1.0-fold (0.00 log units) below the measured one; low and high end bracket the measured number.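

In this assay, 2-chlorophenyl on this saturated ring carbon gives a readable number with a 4-fluorophenyl group on the core as well, not only with the 4-chlorophenyl group of compound 1. Compound 2 and compound 3 each read as a limit and not a number, so the steps from them give only a floor: an at least 1.1-fold lower number from compound 2 to compound 4 (0.04 log units; that floor lies within the scatter) and an at least 1.1-fold lower number from compound 3 to compound 4 (0.04 log units; that floor lies within the scatter). Fluoro for chloro on the other aromatic ring leaves the number unmoved: a 1.0-fold higher number from compound 1 to compound 4 (0.00 log units; within the scatter). Still open, from the compounds shown here alone, is whether a phenyl group carrying an amine or a carboxylic acid on this carbon would move the number beyond the scatter.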